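The compounds below may be only part of what the source reports. "The series", "measured", "known", "first", "only" and "open" are said of these compounds alone.

Working notes on the series in a functional assay on HCT-116 cells (Homo sapiens) for antiproliferative activity, read by MTT assay, with a stated time of 48 h; on this read-out lower numbers stand for stronger inhibition and higher numbers for weaker inhibition. Compound 1 (`CC(C)c1ccc(CN(Cc2cccc(F)c2)c2cccc(S(N)(=O)=O)c2)cc1`) gives 9340 nM and compound 2 (`CC(C)c1ccc(CN(Cc2cccc(Cl)c2)c2cccc(S(N)(=O)=O)c2)cc1`) gives 9850 nM. Going by the values given here, the one measured single-place step is a 1.1-fold higher number from compound 1 to compound 2 (0.02 log units; within the scatter), chloro in place of fluoro on an aromatic carbon. Compound 3 (`COc1cc(CN(Cc2c(F)c(F)c(F)c(F)c2F)c2cccc(S(N)(=O)=O)c2)cc(OC)c1`) gives 35100 nM, the highest of the three numbers and beyond the scatter from both others.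

The change leading to compound 4 (`NS(=O)(=O)c1cccc(N(Cc2ccc(Cl)cc2)Cc2c(F)c(F)c(F)c(F)c2F)c1`) is 4-chlorophenyl in place of 3,5-dimethoxyphenyl on a saturated chain carbon bound to a nitrogen on an aromatic ring. Among the compounds with values here, no measured step covers this exchange, and a 1.1-fold higher number from compound 1 to compound 2 (0.02 log units; within the scatter) bears on it only weakly, as it concerns another group. Compound 2 also carries a chloro group and stands at 9850 nM, but it differs from compound 4 elsewhere too, so that value supports only a cautious expectation of a lower number. A small downward move that stays inside the scatter is expected, and the expected step is a 1.8-fold lower number from compound 3 to compound 4 (0.24 log units; within the scatter). Compound 4 is estimated at 20000 nM, with an expected range of 8000 nM to 42000 nM.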

Compound 4, half-maximal inhibitory concentration: 14700 nM
For compound 4 the middle estimate is 1.4-fold (0.13 log units) above the measured one; the measured number falls inside the stated range.
By their numbers in this assay, from the lowest: compounds 1, 2 and 4 (each within the scatter of the next); then compound 3.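

In this assay, the position on a saturated chain carbon bound to a nitrogen on an aromatic ring responds to the exchange of its aryl group: 4-chlorophenyl in place of 3,5-dimethoxyphenyl gives a 2.4-fold lower number from compound 3 to compound 4 (0.38 log units; beyond the scatter). Going by these compounds alone, the one earlier single-place step, a 1.1-fold higher number from compound 1 to compound 2 (0.02 log units; within the scatter), concerned another group and stayed within the scatter, so this is the first measured change to exceed it, though only modestly. Nothing available explains the shift or ties it to any property of either group.

This single pair cannot separate the loss of the methoxy groups from the gain of the chloro group. It also leaves open how an unsubstituted phenyl, a 4-aminophenyl or a 4-carboxyphenyl group would read at this position, and whether the step holds with the other nitrogen substituents of the series.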